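This account rests on a few compounds, and the source may have more. Where it says the series, first, only, none or still open, it means among the compounds named here.

Measured compounds:
compound 1, `COc1cc(-c2nc(C(c3ccc(F)cc3)c3ccc(F)cc3)sc2CC(=O)O)ccn1`: 60%
compound 2, `O=C(O)Cc1sc(C(c2ccc(F)cc2)c2ccc(F)cc2)nc1-c1ccc(Cl)cc1`: 80%
compound 3, `O=C(O)Cc1sc(C(c2ccccc2)c2ccc(F)cc2)nc1-c1ccc(Cl)cc1`: 80%

In an in vitro functional assay on HEK285-7 cells for antagonist activity at prostaglandin D2 receptor 2 (Homo sapiens), read by BRET and beta-arrestin recruitment (on this read-out lower numbers stand for smaller maximal responses and higher numbers for larger maximal responses), compound 2 gives 80%, the same number at the digits shown as compound 3, and together these two are the highest of the three values, while compound 1 gives 60%.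

Compound 4, `O=C(O)Cc1sc(C(c2ccc(F)cc2)c2ccc(F)cc2)nc1-c1ccnc(Cl)c1`, has not yet been measured in this assay. It differs from compound 2 in one place: 2-chloropyridin-4-yl in place of 4-chlorophenyl on an aromatic carbon. Of the two measured steps, the one that bears on this change is the exchange of the six-membered ring at the same position, where a number 20 percentage points higher from compound 1 to compound 2 (beyond the scatter); the other step, no change at the digits printed from compound 2 to compound 3 (within the scatter), concerns a different part of the molecule and says little here. Since going from a pyridinyl ring to a chlorophenyl ring raised the response, going back from chlorophenyl to a chlorinated pyridinyl ring is expected to lower it, by a step of about a number 15 percentage points lower from compound 2 to compound 4 (beyond the scatter). Compound 4 is therefore estimated at 65%, with a range from 45% to 85%.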

Compound 4, largest response reached (reported as efficacy), in percent of the reference or control that the assay uses: 80%
Compound 4: middle estimate off by 15 percentage points, on the low side, within the range that was stated.
By their numbers in this assay, from the lowest: compound 1; then compounds 2, 3 and 4 (each within the scatter of the next).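

In this assay, putting a ring nitrogen into the six-membered aromatic ring at this position, next to the ring nitrogen of the five-membered ring, gives no change at the digits printed from compound 2 to compound 4 (within the scatter). The earlier gap between a pyridinyl and a phenyl ring therefore does not follow the ring nitrogen in this pair: with that nitrogen kept, chloro in place of methoxy gives a number 20 percentage points higher from compound 1 to compound 4 (beyond the scatter), so the substituent on the ring marks the difference between these compounds. Nothing measured here accounts for this result.

From the compounds shown here alone, whether an amine, a nitrile or a methyl group in place of the chloro would keep the higher number remains open, as does the result for a ring carrying no such group at all. Also open, going by these compounds, is whether hydrogen in place of fluoro on the other part of the molecule would have the same outcome with 2-chloropyridin-4-yl present.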